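Para substituent series on the shared xanthine-like core: fluoro analogue

The compounds below may be only part of what the source reports. "The series", "measured", "known", "first", "only" and "open" are said of these compounds alone.

Measured compounds in an assay for binding affinity to adenosine receptor A1 (Bos taurus); a higher number here means a weaker inhibitor, a lower number a stronger inhibitor:
- compound 1, `Cn1c(=O)c2nc(-c3ccc([N+](=O)[O-])cc3)[nH]c2n(C)c1=O`: 8 nM
- compound 2, `Cn1c(=O)c2nc(-c3ccc(Br)cc3)[nH]c2n(C)c1=O`: 0.75 nM
- compound 3, `CCCCOc1ccc(-c2nc3c(=O)n(C)c(=O)n(C)c3[nH]2)cc1`: 4 nM

Compound 3 gives the second highest of the three numbers. Its nearest neighbour is compound 1, separated by a 2.0-fold lower number from compound 1 to compound 3 (0.30 log units; within the scatter), so the two cannot be told apart. Its furthest is compound 2, with a 5.3-fold higher number from compound 2 to compound 3 (0.73 log units; beyond the scatter), which does stand out. The one large move in the set is an 11-fold lower number from compound 1 to compound 2 (1.03 log units; beyond the scatter).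

The next compound, compound 4, `Cn1c(=O)c2nc(-c3ccc(F)cc3)[nH]c2n(C)c1=O`, has not been measured. Relative to compound 3 the change is fluoro in place of butoxy on an aromatic carbon. Within the data shown here, no fluoro analogue has been measured, so the bearing steps are indirect: the group that enters has one heavy atom, and the only measured group of that kind here is bromo, which gave the strongest number. Bromo in place of butoxy corresponds to reversing a 5.3-fold higher number from compound 2 to compound 3 (0.73 log units; beyond the scatter), a modest but real gain. As far as these compounds go, whether fluoro behaves like bromo here is unknown, so the expectation is a step toward lower numbers but smaller than the bromo case, and possibly within the scatter.

The expected step is therefore a 2.0-fold lower number from compound 3 to compound 4 (0.30 log units; within the scatter). Compound 4 is estimated at 2 nM, with a range from 0.7 nM to 6 nM.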

Compound 4, half-maximal inhibitory concentration: 3.5 nM
Estimate against measurement, compound 4: 1.8-fold (0.24 log units) below, within the range that was stated.
By their numbers in this assay, from the lowest: compound 2; then compounds 4, 3 and 1 (each within the scatter of the next, the first and the last beyond it).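

In this assay, the step of a 1.1-fold lower number from compound 3 to compound 4 (0.06 log units; within the scatter) shows that, on this aromatic carbon, exchanging butoxy with its 5 heavy atoms for fluoro with its 1 heavy atom leaves no readable difference, so heavy-atom count alone does not set the number across these two groups. The step of a 4.7-fold higher number from compound 2 to compound 4 (0.67 log units; beyond the scatter) separates two groups with 1 heavy atom each, which ties the low number of compound 2 to bromo itself rather than to any single-atom group at this place. The step of a 2.3-fold lower number from compound 1 to compound 4 (0.36 log units; beyond the scatter) lies beyond the scatter, while the step of a 2.0-fold lower number from compound 1 to compound 3 (0.30 log units; within the scatter) lies within it, so nitro is separated from fluoro but not from butoxy, even though fluoro and butoxy cannot be told apart; the series therefore gives no clean ranking beyond the standing of compound 2.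

As far as these compounds go, whether chloro or iodo would track bromo or fluoro remains open, as does the behaviour of an amine, a carboxylic acid or a longer alkoxy chain at this place. Nothing available here explains why bromo stands apart from the other three groups.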